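The source may report more compounds than this note shows. Statements on the series, on what has been measured and on what is new or still open speak of the compounds shown alone.

Measured so far:
compound 1 `COc1cccc(NC(=O)c2c(NC(=O)C(F)(F)F)sc3c2CCCCC3)c1` gives 37600 nM
compound 2 `COc1ccc(NC(=O)c2c(NC(=O)C(F)(F)F)sc3c2CCCC3)cc1` gives > 50000 nM as a limit
compound 3 `COc1ccc(NC(=O)c2c(NC(=O)C(F)(F)F)sc(C)c2C)cc1` gives > 50000 nM as a limit

Among the compounds with values here, in an ADME assay on THP-1 cells (Homo sapiens) for cytotoxicity (on this read-out lower numbers stand for higher toxicity in this test and higher numbers for lower toxicity in this test), compound 1 holds the only actual number of the three. The other two stand at the limit of > 50000 nM in this assay, at which 2 of the 3 values shown sit, and give no number.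

Compound 4 `Cc1ccc(NC(=O)c2c(NC(=O)C(F)(F)F)sc3c2CCCCC3)cc1` is not yet measured. It differs from compound 1 by 4-methylphenyl in place of 3-methoxyphenyl on an amide-type nitrogen, with 4-methylphenyl in place of 3-methoxyphenyl on an amide-type nitrogen. Within the data shown here, no measured pair shows this change, so the expectation rests on compound 1 at 37600 nM alone. The expected 1.2-fold lower number from compound 1 to compound 4 (0.07 log units; within the scatter) stays within the usual scatter, with no firm direction, and a report as a limit remains possible. For compound 4 the estimated value is 32000 nM, with an expected range from 14000 nM to 50000 nM in this read-out.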

Compound 4, half-maximal cytotoxic concentration: > 50000 nM
Compound 4: a limit, no number; the forecaster's own chance of this, stated with the estimate: 30%; middle value at least 1.5-fold (0.19 log units) from the limit.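

In this assay, 4-methylphenyl in place of 3-methoxyphenyl on an amide-type nitrogen gives an at least 1.3-fold higher number from compound 1 to compound 4 (0.12 log units; that floor lies within the scatter). Compound 4 is a limit and not a number, so this step is a floor only and its true size cannot be read. With the core of compound 1 held, this change at this place gives no lower number, and the read-out offers little room to separate the compounds: the limit of > 50000 nM in this assay, at which 3 of the 4 values shown sit.

Compounds at the limit cannot be ordered among themselves. From the compounds shown here alone, whether an aryl group carrying an amine or a carboxylic acid on this nitrogen would give a clearly lower number stays open.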